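A methylcarbamoyl group takes the place of 1,3-thiazol-2-yl

The source may hold more compounds than are shown below. What is called first, only, known or untested is meant among the compounds shown, and "the series" means these compounds.

In a functional assay on blood (Homo sapiens), with a stated time of 60 min, in the presence of a further agent that is not named here (on this read-out lower numbers stand for an effect already at smaller amounts and higher numbers for an effect only at larger amounts of compound), compound 1 `O=C(O)C1(S(=O)(=O)c2ccc(Oc3ccc(OC(F)(F)F)cc3)cc2)CCC2(CCNCC2)C1` gives 1800 nM. Compound 2 `O=S(=O)(c1ccc(Oc2ccc(OC(F)(F)F)cc2)cc1)C1(CO)CCC2(CCNCC2)C1` gives > 15000 nM, which is a limit. Compound 3 `O=C(Nc1nccs1)C1(S(=O)(=O)c2ccc(Oc3ccc(OC(F)(F)F)cc3)cc2)CCC2(CCNCC2)C1` gives > 15000 nM, also a limit, and so stands at the limit of > 15000 nM in this assay, at which 2 of the 3 values shown sit. Compound 4 `CNC(=O)NC(=O)C1(S(=O)(=O)c2ccc(Oc3ccc(OC(F)(F)F)cc3)cc2)CCC2(CCNCC2)C1` carries methylcarbamoyl in place of 1,3-thiazol-2-yl on an amide-type nitrogen. For the measured compounds named here, no measured step covers this change directly. The nearest are an at least 8.3-fold higher number from compound 1 to compound 3 (0.92 log units; beyond the scatter) and an at least 8.3-fold higher number from compound 1 to compound 2 (0.92 log units; beyond the scatter), both beyond the scatter, and compound 4 likewise lacks the carboxy group of compound 1. A return towards compound 1 is therefore not expected, and the expected step is small: a number no higher from compound 3 to compound 4 (the limit leaves the size open). For compound 4 the estimated value is 15000 nM, with an expected range of 5000 nM to 30000 nM.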

Compound 4, half-maximal effective concentration: < 400 nM
Compound 4 gave a limit, no number; the forecaster's own chance of this, stated with the estimate: 65%; at least 37-fold (1.57 log units) between middle value and limit.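

In this assay compound 4 gives a limit and not a number: the limit of < 400 nM in this assay, at which 1 of the 4 values shown sits.

Methylcarbamoyl in place of 1,3-thiazol-2-yl on the amide-type nitrogen brings an at least 37-fold lower number from compound 3 to compound 4 (1.57 log units; beyond the scatter), so the group on this nitrogen decides much of the read-out. The same (methylcarbamoyl)carbamoyl group brings an at least 37-fold lower number from compound 2 to compound 4 (1.57 log units; beyond the scatter) and an at least 4.5-fold lower number from compound 1 to compound 4 (0.65 log units; beyond the scatter), so among these compounds the carboxy group is not needed for an effect at smaller amounts.

As far as these compounds go, the true size of these steps stays open. So does whether an acetyl group or the longer ethylcarbamoyl on the same nitrogen would keep this effect.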